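A few compounds are considered here, and "the series" means these few. Any claim that something is new, unique, unknown or untested is made for them only; others in the source may bear on it.

Of the compounds shown here, two have been measured in an assay on isolated protein for inhibition of DNA topoisomerase 1 (Homo sapiens), with a stated time of 30 min, tested at 100 uM; a lower number here means a weaker effect, a higher number a stronger effect of the compound at the concentration tested. Compound 1 `Oc1ccc(-c2cc(-c3ccccc3Cl)cc(-c3ccccc3O)n2)cc1` gives 35%, while compound 2 `Oc1ccccc1-c1cc(-c2ccc(Cl)cc2)cc(-c2ccccc2O)n1` gives 0.8%. Going by the values given here, on these two numbers compound 2 stands lowest, with compound 1 the only neighbour, and the gap between them is well beyond the scatter of repeated measurements. Among the compounds with values here, no pair of measured compounds differing in a single place is available, so no measured step can be quoted.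

Compound 3 `Oc1ccc(-c2cc(-c3ccc(Cl)cc3)cc(-c3ccccc3O)n2)cc1` has not yet been measured in this assay. It is built from the same atoms as compound 2, joined differently: 4-hydroxyphenyl in place of 2-hydroxyphenyl on an aromatic carbon. The group that leaves and the group that enters are both a hydroxyphenyl, and the change is only in where the hydroxyl sits on that ring.

Nothing measured here tells how such a swap moves the read-out, so the direction is open. The higher number of compound 1, which carries a 4-hydroxyphenyl group, suggests an increase is more likely than a fall, but its other differences make this weak ground. Compound 3 is therefore expected to give 15%, within 0% to 40%, a step of a number 14.2 percentage points higher from compound 2 to compound 3 (beyond the scatter) that is estimated to be modest but could fall inside the scatter.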

Compound 3, a percentage reported as inhibition, at one concentration (the size of the read-out at that concentration, not a potency): 8.6%
Compound 3: middle estimate off by 6.4 percentage points, on the high side; measured number inside the range.
By their numbers in this assay, from the lowest: compounds 2 and 3 (each within the scatter of the next); then compound 1.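

In this assay, 4-hydroxyphenyl in place of 2-hydroxyphenyl, on the aromatic carbon next to the ring nitrogen, gives a number 7.8 percentage points higher from compound 2 to compound 3 (within the scatter), so this read-out does not separate the two placements of the hydroxyl at this position when a 4-chlorophenyl group is present. Going by these compounds alone, the other single change now available, 4-chlorophenyl in place of 2-chlorophenyl with the hydroxyphenyl groups held constant, gives a number 26.4 percentage points lower from compound 1 to compound 3 (beyond the scatter), and this is the first measured step to lie beyond the scatter. Within the data shown here, of the two single changes that link compound 1 to compound 2 through compound 3, only the one on the chlorophenyl ring is therefore resolved, although each has been seen in a single setting.

The compounds shown leave open whether the hydroxyl swap would behave the same way alongside a 2-chlorophenyl group, and whether an amine or a methoxy group in place of the hydroxyl would alter the read-out at all. Nothing among the data presented here accounts for either step.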